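Amine Swap on a Thiocarbonyl Carbon and Cell Growth

A few compounds are considered here, and "the series" means these few. Any claim that something is new, unique, unknown or untested is made for them only; others in the source may bear on it.

Three compounds have been measured in a functional assay on LM7 cells (Homo sapiens) for antiproliferative activity, read by MTT assay, with a stated time of 72 h; on this read-out lower numbers stand for stronger inhibition and higher numbers for weaker inhibition:

compound 1 `CC(C)N(C(=S)SCc1oc2ccccc2c(=O)c1Cl)C(C)C`: > 40000 nM
compound 2 `Cc1ccc2c(=O)c(CSC(=S)N3CCCC3)coc2c1`: 3400 nM
compound 3 `O=c1c(Cl)c(CSC(=S)N2CCCC2)oc2ccccc12`: 1900 nM

The entry for compound 1 is not a number but a limit of the assay, (the limit of > 40000 nM in this assay, at which 1 of the 3 values shown sits). Compounds 2 and 3 carry the same pyrrolidin-1-yl group but sit on different cores; the difference between the two cores is not broken down here, and their two values lie within the usual scatter of each other. Compound 1 differs from compound 3 in one place: diisopropylamino in place of pyrrolidin-1-yl on a thiocarbonyl carbon. This change brought an at least 21-fold higher number from compound 3 to compound 1 (1.32 log units; beyond the scatter).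

Compound 4 `Cc1ccc2c(=O)c(CSC(=S)N(C(C)C)C(C)C)coc2c1` has not been measured yet. It differs from compound 2 in exactly the same way: diisopropylamino in place of pyrrolidin-1-yl on a thiocarbonyl carbon. A step of comparable size is expected here, namely an 18-fold higher number from compound 2 to compound 4 (1.25 log units; beyond the scatter), because the same change produced an at least 21-fold higher number from compound 3 to compound 1 (1.32 log units; beyond the scatter) when it was made on the core of compound 3. Starting from the value that compound 2 shows, 3400 nM, compound 4 is therefore expected to land around 60000 nM.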

Compound 4, half-maximal inhibitory concentration: 6300 nM
Estimate against measurement, compound 4: 9.5-fold (0.98 log units) above, and the stated range ends above it.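

In this assay, the swap on the core of compound 2 gave a 1.9-fold higher number from compound 2 to compound 4 (0.27 log units; within the scatter), so on this core, replacing pyrrolidin-1-yl with diisopropylamino has no effect that can be told apart from the usual scatter. A step seen on one core therefore did not carry over in size to the other, and the two steps clearly differ: the same change on two cores in this assay, an at least 21-fold higher number (1.32 log units; beyond the scatter) from compound 3 to compound 1 and a 1.9-fold higher number (0.27 log units; within the scatter) from compound 2 to compound 4, at least 11-fold (1.05 log units) apart, beyond the scatter of two such steps

These two cores alone do not show which part of a core decides the size of the step, or how the change would behave on any further core. Compound 1 holds a limit of the assay rather than a number, so the full size of its step is not known: the limit of > 40000 nM in this assay, at which 1 of the 4 values shown sits.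

The compounds shown leave open whether a third amine on the thiocarbonyl carbon, such as morpholine or dimethylamine, would follow compound 1 or compound 4. They also leave open whether the core of compound 3 or that of compound 2 is the more typical when the same swap is made on other cores in this series.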